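The source may hold more compounds than are shown below. What is called first, only, known or untested is meant among the compounds shown, and "the series" means these compounds.

Compound 1 `COC(CCn1cnc2c(NCc3ccc(C(=O)Nc4ccccc4N)cc3)nc(Cl)nc21)OC`: 6.39%
Compound 2 `Cc1ccc(Nc2nc(Cl)nc3c2ncn3Cc2ccc(C(=O)Nc3ccccc3N)cc2)cc1`: 76.3%

In a functional assay on HCT-116 cells (Homo sapiens) for antiproliferative activity, read by CCK-8 assay, with a stated time of 72 h, tested at 2 uM (a lower number here means a weaker effect, a higher number a stronger effect of the compound at the concentration tested), compound 1 gives 6.39%, the lowest of the two numbers, with compound 2 at 76.3% well beyond the scatter above it. The two differ in more than one place, so their gap is not traced to a single change. Compound 3 `CCCn1cnc2c(NCc3ccc(C(=O)Nc4ccccc4N)cc3)nc(Cl)nc21` differs from compound 1 by one change: methyl in place of dimethoxymethyl on a saturated chain carbon, two bonds along the chain from an aromatic nitrogen. Within the data shown here, no measured pair shows this change, so no step beyond the scatter is expected; the step from compound 1 to compound 3 is estimated as a number 3.6 percentage points higher from compound 1 to compound 3 (within the scatter). Compound 3 is thus expected to give 10%, between 0% and 35%.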

Compound 3, a percentage reported as inhibition, at one concentration (the size of the read-out at that concentration, not a potency): 28.5%
Compound 3: middle estimate off by 18.5 percentage points, on the low side, within the range that was stated.
By their numbers in this assay, from the lowest: compound 1; then compound 3; then compound 2.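

The change from 3,3-dimethoxypropyl to propyl, with methyl in place of dimethoxymethyl, gives a number 22.1 percentage points higher from compound 1 to compound 3 (beyond the scatter) in this assay and so shows that this chain position responds to the group it carries. At this position the dimethoxymethyl group, with its two hydrogen-bond acceptors, is not needed for the effect, since methyl, with none, reads higher. Nothing in the data shown accounts for this step. Still open, on these data alone, is how an amine, a carboxylic acid or a longer chain would read at this position, and whether the same change would give a similar step on another core.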